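The source may hold more compounds than are shown below. What is called first, only, known or untested is meant among the compounds shown, and "the series" means these compounds.

Measured so far in a functional assay on MGC-803 cells (Homo sapiens) for inhibition, read by MTT assay, with a stated time of 72 h; on this read-out higher numbers stand for weaker inhibition and lower numbers for stronger inhibition:
Compound 1 `O=C(CSc1nc(Nc2ccccc2)c2ccccc2n1)Nc1ccc(F)cc1` gives > 50000 nM, which is a limit of the assay.
Compound 2 `C=CC(=O)Nc1cccc(NC(=O)CSc2nc(Nc3ccccc3Br)c3ccccc3n2)c1` gives 12800 nM.
Compound 3 `C=CC(=O)Nc1cccc(NC(=O)CSc2nc(Nc3ccccc3C)c3ccccc3n2)c1` gives 30200 nM.

Going by the values given here, compound 3 has the higher of the two numbers in this assay; its nearest neighbour is compound 2, and the only step with a number at both ends is a 2.4-fold higher number from compound 2 to compound 3 (0.37 log units; beyond the scatter). One of the three values is a limit only: the limit of > 50000 nM in this assay, at which 1 of the 3 values shown sits. The measured range is therefore narrow.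

Compound 4 `C=CC(=O)Nc1cccc(NC(=O)CSc2nc(Nc3cccc([N+](=O)[O-])c3)c3ccccc3n2)c1` differs from compound 3 in one place: 3-nitrophenyl in place of 2-methylphenyl on a nitrogen on an aromatic ring. Among the compounds with values here, no measured step exchanges the group on that nitrogen in this way; the single measured step, a 2.4-fold higher number from compound 2 to compound 3 (0.37 log units; beyond the scatter), swaps two substituents on the same ring and was modest. On that basis no step beyond the scatter is expected from compound 3 to compound 4. The nitro substituent has no measured counterpart in the series, and the range is set wide for that reason alone. Compound 4 is therefore estimated in this assay at 25000 nM, between 8000 nM and 80000 nM. The expected step is a 1.2-fold lower number from compound 3 to compound 4 (0.08 log units; within the scatter), with a real chance that only a limit is returned.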

Compound 4, half-maximal inhibitory concentration: > 50000 nM
Compound 4 gave a limit, no number (the forecaster's own chance of this, stated with the estimate: 25%); at least 2.0-fold (0.30 log units) between middle value and limit.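

In this assay the group on this nitrogen proves able to remove any measurable activity from the series: compound 4 gives > 50000 nM, which is a limit of the assay and not a number. The exchange of 2-bromophenyl for 3-nitrophenyl gives an at least 3.9-fold higher number from compound 2 to compound 4 (0.59 log units; beyond the scatter), whereas the exchange of 2-methylphenyl for 3-nitrophenyl gives an at least 1.6-fold higher number from compound 3 to compound 4 (0.21 log units; that floor lies within the scatter), so only the first of these two steps is shown to exceed the scatter. The earlier step between the two substituted phenyl groups showed only a modest shift, whereas this change at the same nitrogen is enough to bring a compound of the series to the ceiling of the read-out: the limit of > 50000 nM in this assay, at which 2 of the 4 values shown sit.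

As far as these compounds go, how far compound 4 truly lies from compound 3 cannot be read from a limit, and it remains open whether the loss goes with the nitro group itself or with the place it holds on the ring. Also open, from the compounds shown here alone, is whether an amine or a methoxy group on that phenyl ring would return a number, and how such a compound would stand against compound 2.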